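Lactam in place of amide on the shared core

The source may report more compounds than this note shows. Statements on the series, on what has been measured and on what is new or still open speak of the compounds shown alone.

Three compounds of the series have been run in an ADME assay on microsomes from liver (Homo sapiens) for metabolic stability, read by LC-MS, using NADPH, with stated times of 5 min and 30 min, tested at 1 uM; a higher number here means faster removal of the compound, a lower number slower removal. Compound 1, `Cc1ncccc1-c1cnc(NCc2c(F)ccc3c2CCO3)c2nn(CC#N)c(=O)n12`, gives 151 mL.min-1.g-1. Compound 2, `COCCC(=O)Nc1cnc(NCc2c(F)ccc3c2CCO3)n2cnnc12`, returns only a limit in this assay, < 3 mL.min-1.g-1. Compound 3, `CN(C)Cc1ccc(C(=O)Nc2cnc(NCc3c(F)ccc4c3CCO4)n3cnnc23)cc1`, gives 13 mL.min-1.g-1 in this assay. For the measured compounds named here, the single step measured so far, an at least 4.3-fold higher number from compound 2 to compound 3 (0.63 log units; beyond the scatter), is 4-((dimethylamino)methyl)phenyl in place of 2-methoxyethyl on a carbonyl carbon. Compound 2 therefore stands at the floor of the numbers shown, at the limit of < 3 mL.min-1.g-1 in this assay, at which 1 of the 3 values shown sits, so only a ceiling is known for it, not a number.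

Compound 4, `O=C1CCCN1c1cnc(NCc2c(F)ccc3c2CCO3)n2cnnc12`, is not yet measured in this assay. It differs from compound 2 as follows: 2-oxopyrrolidin-1-yl in place of ((2-methoxyethyl)carbonyl)amino on an aromatic carbon. The step already measured does not touch this change: it alters the group on the carbonyl carbon and keeps the amide, whereas here the whole ((2-methoxyethyl)carbonyl)amino group departs and 2-oxopyrrolidin-1-yl enters. There is thus no measured guide for the direction. Since compound 2 sits at a limit, any number above it is an upward step; a small one, an at least 1.6-fold higher number from compound 2 to compound 4 (0.22 log units; that floor lies within the scatter), is expected, likely within the scatter. Compound 4 is expected at 5 mL.min-1.g-1, with a range of 2 mL.min-1.g-1 to 14 mL.min-1.g-1.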

Compound 4, intrinsic clearance in microsomes: < 3 mL.min-1.g-1
Compound 4: only a limit was reported (the forecaster's own chance of this, stated with the estimate: 35%); middle value at least 1.6-fold (0.22 log units) from the limit.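

In this assay, for the compounds shown here, compound 4 returns < 3 mL.min-1.g-1, a limit and not a number; compound 2 also carries only a limit, so no step between compound 2 and compound 4 can be read. Left open is whether 2-oxopyrrolidin-1-yl and ((2-methoxyethyl)carbonyl)amino differ at all on the shared core, as both compounds rest at the same floor: the limit of < 3 mL.min-1.g-1 in this assay, at which 2 of the 4 values shown sit.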